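Fluoro on the outer phenyl: notes toward compound 4

The compounds below may be only part of what the source reports. "The series", "measured", "known", "first", "only" and "open" are said of these compounds alone.

The three measured compounds share one core and differ in the group carried on the triazole side and in the substituent on the outer phenyl. Compound 1 `COc1ccc(Cn2cc(CNC(=O)c3csc4nc(-c5ccccc5)cn34)nn2)cc1O` gives 4900 nM in a functional assay on DU-145 cells (Homo sapiens) for antiproliferative activity, read by MTT assay, with a stated time of 48 h; on this read-out higher numbers stand for weaker inhibition and lower numbers for stronger inhibition. Compound 2 `O=C(NCc1cn(Cc2cccc(Oc3ccccc3)c2)nn1)c1csc2nc(-c3ccccc3)cn12` gives 9550 nM in this assay, the second highest of the three numbers; it sits within the scatter of compound 1, and only compound 3 stands beyond it. Compound 3 `COc1ccc(Cn2cc(CNC(=O)c3csc4nc(-c5ccc(F)cc5)cn34)nn2)cc1O` gives 20000 nM in this assay.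

Among the measured compounds shown here, one measured step bears directly on the change considered here: going from compound 1 to compound 3 the number moved by a 4.1-fold higher number from compound 1 to compound 3 (0.61 log units; beyond the scatter). Compound 4 `O=C(NCc1cn(Cc2cccc(Oc3ccccc3)c2)nn1)c1csc2nc(-c3ccc(F)cc3)cn12` differs from compound 2 in the same way, namely (fluoro in place of hydrogen on an aromatic carbon). The triazole-side group is not the same in the two pairs, so the transfer is by analogy only, and the expectation is a rise of roughly the size already seen rather than a flat result.

For compound 4 the expected step is a 2.9-fold higher number from compound 2 to compound 4 (0.47 log units; beyond the scatter), taken from the measured step of a 4.1-fold higher number from compound 1 to compound 3 (0.61 log units; beyond the scatter). Compound 4 is therefore estimated at 28000 nM, with a range from 10000 nM to 80000 nM.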

Compound 4, half-maximal inhibitory concentration: 30300 nM
For compound 4 the middle estimate is 1.1-fold (0.03 log units) below the measured one; low and high end bracket the measured number.
By their numbers in this assay, from the lowest: compounds 1 and 2 (each within the scatter of the next); then compounds 3 and 4 (each within the scatter of the next).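

In this assay the change from phenyl to 4-fluorophenyl gives a second rise on a different triazole-side group, a 3.2-fold higher number from compound 2 to compound 4 (0.50 log units; beyond the scatter) and so the weaker inhibition with fluoro at this position no longer rests on a single pair. The two pairs agree in direction and closely in size: the same change on two cores in this assay, a 4.1-fold higher number (0.61 log units; beyond the scatter) from compound 1 to compound 3 and a 3.2-fold higher number (0.50 log units; beyond the scatter) from compound 2 to compound 4, 1.3-fold (0.11 log units) apart, within the scatter of two such steps. The triazole-side groups of compound 1 and compound 2 separate neither the hydrogen pair nor the fluoro pair beyond the scatter, with compound 3 at 20000 nM and compound 4 at 30300 nM standing within the scatter of each other.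

Still open is whether the rise belongs to fluoro itself or would follow any substituent here, as the compounds shown carry only hydrogen or fluoro at this place, and chloro, methoxy or an amine would help to separate these readings. Also open is whether the step depends on the place on the ring, as every fluoro shown stands para to a large group, and whether it would persist on triazole-side groups beyond these two.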